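Imidazol-1-yl in place of pyridin-3-yl on the shared core

A few compounds are considered here, and "the series" means these few. Any claim that something is new, unique, unknown or untested is made for them only; others in the source may bear on it.

Working notes on the series. All three measured compounds share one core that carries a pyridin-3-yl group and a short chain bound to an aromatic nitrogen. Compound 1 `CCn1nc(-c2cccnc2)c2ccccc2c1=O` is the reference; in an assay on isolated protein (Oryctolagus cuniculus) with Thromboxane-A synthase (Homo sapiens) as the target, tested at 1 uM (on this read-out higher numbers stand for more inhibition at the one concentration tested (going by the name of the read-out) and lower numbers for less inhibition), compound 1 gives 87%, the head of the three numbers shown. Compound 2 `CCCn1nc(-c2cccnc2)c2ccccc2c1=O` gives 86% in this assay, and the step of a number 1 percentage points lower from compound 1 to compound 2 (within the scatter) is within the scatter, so the two are not ordered. Compound 3 `CC(=O)Cn1nc(-c2cccnc2)c2ccccc2c1=O` gives 13% in this assay; the step of a number 74 percentage points lower from compound 1 to compound 3 (beyond the scatter) and the parallel step a number 73 percentage points lower from compound 2 to compound 3 (beyond the scatter) are both large.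

Compound 4 `CCn1nc(-n2ccnc2)c2ccccc2c1=O` differs from compound 1 by 1H-imidazol-1-yl in place of pyridin-3-yl on an aromatic carbon. Among the measured compounds shown here, none of the measured steps touches this part of the core: all three concern the chain bound to the aromatic nitrogen, and the pyridin-3-yl group is kept unchanged in compound 1, compound 2 and compound 3 alike. The measured steps therefore give no direct guide to the size or direction of the step in this assay, and the outcome is open in both directions. Without a comparable step, the working expectation for compound 4 is a value in this assay of 70%, with a range from 30% to 95%. This estimate corresponds to an expected step of a number 17 percentage points lower from compound 1 to compound 4 (beyond the scatter).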

Compound 4, a percentage reported as inhibition, at one concentration (the size of the read-out at that concentration, not a potency): 53%
Compound 4: middle estimate off by 17 percentage points, on the high side; the range from low to high includes it.
By their numbers in this assay, from the lowest: compound 3; then compound 4; then compounds 2 and 1 (each within the scatter of the next).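

The step of a number 34 percentage points lower from compound 1 to compound 4 (beyond the scatter) in this assay shows that the aromatic carbon carrying the pyridin-3-yl group is sensitive to what it holds, which the chain changes among compound 1, compound 2 and compound 3 could not show; the loss is only partial, since compound 4 still gives 53%. The change replaces one six-membered aromatic ring with 1 hetero atom by one five-membered aromatic ring with 2 hetero atoms, so ring size and hetero atom count change together and this single step cannot be divided between them. No measurement offered here accounts for the size of the step.

Open, going by these compounds, is how other groups would read at this aromatic carbon, such as phenyl, which has no ring nitrogen, pyridin-4-yl, which keeps the six-membered ring, or 1H-imidazol-4-yl, which keeps the five-membered ring. Also open, on these data alone, is whether a step of this size would carry over to the propyl chain of compound 2 or the acetyl-bearing chain of compound 3.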